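Swapping the pyridine attachment point on a weak antiproliferative core

The source may hold more compounds than are shown below. What is called first, only, known or untested is meant among the compounds shown, and "the series" means these compounds.

Measured compounds:
- compound 1 `Cc1cn2c(/C=N/NC(=N)N)c(-c3ccncc3)nc2s1`: 17400 nM
- compound 2 `Cc1sc2nc(-c3ccncc3)c(/C=N/NC(=N)N)n2c1C`: 55000 nM
- compound 3 `N=C(N)N/N=C/c1c(-c2ccncc2)nc2sc(Cl)cn12`: 17400 nM

In a functional assay on prostate cells (Homo sapiens) for antiproliferative activity (a lower number here means a stronger inhibitor of growth, a higher number a weaker inhibitor of growth), compound 1 gives 17400 nM. It stands level with compound 3 within the scatter, and the two share the lowest number of the three; compound 2 sits furthest away, a 3.2-fold higher number from compound 1 to compound 2 (0.50 log units; beyond the scatter). The step of no change at the digits printed from compound 1 to compound 3 (within the scatter) shows that exchanging one small group for another on the five-membered part of the shared core leaves the number unchanged.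

Compound 4 `Cc1cn2c(/C=N/NC(=N)N)c(-c3ccccn3)nc2s1` has not yet been measured in this assay. It differs from compound 1 only in pyridin-2-yl in place of pyridin-4-yl on an aromatic carbon. Among the measured compounds shown here, none of the measured steps touches this pyridine ring: the two known steps alter the small group on the five-membered ring of the shared core, one with no change and one with a modest rise. They therefore give no direction for the present change, and no step beyond the scatter is expected, with a wide range either way. Compound 4 is estimated to show 20000 nM (range 6000 nM to 60000 nM), which would correspond to an expected step of a 1.1-fold higher number from compound 1 to compound 4 (0.06 log units; within the scatter).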

Compound 4, concentration for 50% growth inhibition: 7940 nM
Estimate against measurement, compound 4: 2.5-fold (0.40 log units) above; measured number inside the range.
By their numbers in this assay, from the lowest: compound 4; then compounds 1 and 3 (each within the scatter of the next); then compound 2.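

In this assay, changing only where the pyridine ring is joined to the shared core gives a 2.2-fold lower number from compound 1 to compound 4 (0.34 log units; beyond the scatter). Among the compounds shown here, the two rings have the same atoms, so the way the ring is joined is enough to move the number beyond the scatter, a modest effect at a place that the earlier steps, which changed only the small groups on the five-membered ring, did not touch. No measurement available here accounts for this shift.

The compounds shown leave open how pyridin-3-yl or a plain phenyl ring, which has no ring nitrogen, would behave at this carbon. They also leave open whether pyridin-2-yl would bring a similar step on the cores of compound 2 and compound 3.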